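Three measured amides, a fourth still waiting

A few compounds are considered here, and "the series" means these few. Any claim that something is new, unique, unknown or untested is made for them only; others in the source may bear on it.

compound 1 `O=C(Nc1cccc(-c2oc3cc(-c4ccc(F)cc4)ccc3c(=O)c2O)c1)c1ccc(Cl)cc1`: 9140 nM
compound 2 `Cc1ccccc1C(=O)Nc1cccc(-c2oc3cc(-c4ccc(F)cc4)ccc3c(=O)c2O)c1`: 24800 nM
compound 3 `Cc1cc(C(=O)Nc2cccc(-c3oc4cc(-c5ccc(F)cc5)ccc4c(=O)c3O)c2)ccc1F`: 12100 nM

Three compounds share one core and differ only in the aryl group on the carbonyl carbon of the amide. In a functional assay on GTL 16 cells for antiproliferative activity against GTL 16 cell line (Homo sapiens), read by CCK-8 assay, with a stated time of 72 h (on this read-out lower numbers stand for stronger inhibition and higher numbers for weaker inhibition), compound 1 gives 9140 nM, the lowest of the three numbers. Compound 3, with 12100 nM, sits within the scatter of it, while compound 2, with 24800 nM, lies beyond it. Going by the values given here, the steps read a 2.7-fold higher number from compound 1 to compound 2 (0.43 log units; beyond the scatter), a 1.3-fold higher number from compound 1 to compound 3 (0.12 log units; within the scatter) and a 2.0-fold lower number from compound 2 to compound 3 (0.31 log units; beyond the scatter), so the only change that clearly moves the number is the one to 2-methylphenyl.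

Compound 4 `O=C(Nc1cccc(-c2oc3cc(-c4ccc(F)cc4)ccc3c(=O)c2O)c1)c1cc(F)cc(F)c1` is the next member. Relative to compound 1 the change is 3,5-difluorophenyl in place of 4-chlorophenyl on a carbonyl carbon. The step that bears on it most directly is a 1.3-fold higher number from compound 1 to compound 3 (0.12 log units; within the scatter), since compound 3 also carries fluorine on that ring and stays within the scatter of compound 1; the step of a 2.7-fold higher number from compound 1 to compound 2 (0.43 log units; beyond the scatter) shows that a different aryl can still shift the number modestly upward. On that basis compound 4 is expected to land close to compound 1, with a 1.3-fold higher number from compound 1 to compound 4 (0.12 log units; within the scatter) as the estimated step, within the scatter or at most a modest rise. Compound 4 is therefore estimated at 12000 nM, with a range from 5000 nM to 30000 nM.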

Compound 4, half-maximal inhibitory concentration: 7410 nM
For compound 4 the middle estimate is 1.6-fold (0.21 log units) above the measured one; measured number inside the range.
By their numbers in this assay, from the lowest: compounds 4, 1 and 3 (each within the scatter of the next); then compound 2.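

In this assay, the new compound shows that this position on the carbonyl carbon accepts a different halogen pattern without a readable change: replacing 4-chlorophenyl with 3,5-difluorophenyl gives a 1.2-fold lower number from compound 1 to compound 4 (0.09 log units; within the scatter), and replacing 4-fluoro-3-methylphenyl with it gives a 1.6-fold lower number from compound 3 to compound 4 (0.21 log units; within the scatter), so compounds 1, 3 and 4 form one group that these values do not separate. Going by these compounds alone, compound 2 remains the only one that stands apart, now with a 3.3-fold lower number from compound 2 to compound 4 (0.52 log units; beyond the scatter), the largest step, and its 2-methylphenyl group is the only aryl here whose steps to all the others lie beyond the scatter. No measurement given here accounts for either the flat stretch or the rise at compound 2.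

The compounds shown leave open whether the rise at compound 2 belongs to the 2-methyl group itself or would also appear with another group in that place on the ring, such as 2-chlorophenyl or 2-methoxyphenyl. They also leave open how the number would respond to an aryl carrying an amine or a carboxylic acid, or to a plain alkyl chain in place of the aryl on this carbonyl carbon.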